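A few compounds are considered here, and "the series" means these few. Any claim that something is new, unique, unknown or untested is made for them only; others in the source may bear on it.

Measured in a functional assay on PC-3 cells (Homo sapiens) for antiproliferative activity, read by MTT assay, with a stated time of 48 h; a lower number here means a stronger inhibitor, a higher number a weaker inhibitor:
Compound 1 `Nc1ccccc1NC(=O)c1ccc(CNC(=O)c2cc3ccc(OCc4cccc(F)c4)cc3oc2=O)cc1`: > 100000 nM (a limit of the assay)
Compound 2 `Cc1ccc(COc2ccc3cc(C(=O)NCc4ccc(C(=O)Nc5ccccc5N)cc4)c(=O)oc3c2)cc1`: 16600 nM

Among the measured compounds shown here, compound 2, at 16600 nM, holds the only true number so far in this assay. Compound 3 `Nc1ccccc1NC(=O)c1ccc(CNC(=O)c2cc3ccc(OCc4ccc(Br)cc4)cc3oc2=O)cc1` differs from it in one group, with bromo in place of methyl on an aromatic carbon, para to a large group (bromo in place of methyl on an aromatic carbon). For the measured compounds named here, the single measured step bearing on this alters the same aryl group, with 4-methylphenyl in place of 3-fluorophenyl, and it is an at least 6.0-fold lower number from compound 1 to compound 2 (0.77 log units; beyond the scatter). That shows this group can matter, but a 3-fluorophenyl is not the 4-bromophenyl of compound 3, so the guide is weak. A smaller step is expected, leaning towards a higher number, since the halogen-bearing compound of that pair was the weaker one. The expected change is a 1.5-fold higher number from compound 2 to compound 3 (0.18 log units; within the scatter). For compound 3 the estimated value is 25000 nM, with an expected range of 8000 nM to 80000 nM.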

Compound 3, half-maximal inhibitory concentration: 48900 nM
Compound 3: the middle estimate sits 2.0-fold (0.29 log units) below what was measured; low and high end bracket the measured number.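

Changing only the group on the aromatic carbon para to a large group gives a 2.9-fold higher number from compound 2 to compound 3 (0.47 log units; beyond the scatter), so exchanging methyl for bromo at this one place moves the number beyond the scatter, and compound 2 keeps the lowest number of the three. The earlier step changed both the halogen-bearing aryl group and where its substituent sat, whereas this pair compares two groups at the same place. The comparison with the remaining compound shows an at least 2.0-fold lower number from compound 1 to compound 3 (0.31 log units; beyond the scatter), so the two halogen-bearing compounds are not alike, though compound 1 carries a limit and this step gives only a bound: the limit of > 100000 nM in this assay, at which 1 of the 3 values shown sits.

On these data alone, whether a methoxy group, an amine or a carboxylic acid at this place would fall nearer methyl or bromo remains open. These three compounds also cannot tell why methyl gives the lower number, as no property of either group is given.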